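Heteroaryl swap on the saturated ring: compound 3 to compound 4

The compounds below may be only part of what the source reports. "The series", "measured", "known", "first", "only" and "open" are said of these compounds alone.

Compound 1 `CC[C@H](C)[C@H](N)CN(C(=O)[C@@H]1C[C@H]1c1cccc(F)c1)c1ccc(-c2ccccc2)cc1` gives 560 nM in a functional assay for agonist activity at G protein-coupled receptor 88 (Homo sapiens), read by HTRF and cAMP accumulation; on this read-out higher numbers stand for an effect only at larger amounts of compound and lower numbers for an effect already at smaller amounts. Within the data shown here, compound 3 `CC[C@H](C)[C@H](N)CN(C(=O)[C@@H]1C[C@H]1c1cc(F)ccc1F)c1ccc(-c2ccccc2)cc1` gives 770 nM; with a 1.4-fold higher number from compound 1 to compound 3 (0.14 log units; within the scatter), compound 3 stands level with compound 1, the only other numeric value shown. Compound 2 `CC[C@H](C)[C@H](N)CN(C(=O)[C@@H]1C[C@H]1c1ccc(C#N)cc1)c1ccc(-c2ccccc2)cc1` yields only a limit, > 25000 nM. Compound 4 `CC[C@H](C)[C@H](N)CN(C(=O)[C@@H]1C[C@H]1c1nccs1)c1ccc(-c2ccccc2)cc1` remains to be measured; relative to compound 3 it carries 1,3-thiazol-2-yl in place of 2,5-difluorophenyl on a saturated ring carbon. Among the measured compounds shown here, the precedents that bear on this are the earlier exchanges of the aryl group on the saturated ring carbon, an at least 44-fold higher number from compound 1 to compound 2 (1.64 log units; beyond the scatter) and an at least 32-fold lower number from compound 2 to compound 3 (1.51 log units; beyond the scatter), both large, whereas the single fluoro change, a 1.4-fold higher number from compound 1 to compound 3 (0.14 log units; within the scatter), was small. Whole-group replacement has so far moved the number far, once to the limit of > 25000 nM in this assay, at which 1 of the 3 values shown sits. For compound 4 a higher number is therefore expected, a 5.2-fold higher number from compound 3 to compound 4 (0.72 log units; beyond the scatter), estimated at 4000 nM within a range of 800 nM to 25000 nM.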

Compound 4, half-maximal effective concentration: 210 nM
Estimate against measurement, compound 4: 19-fold (1.28 log units) above; measured number below the stated range.
By their numbers in this assay, from the lowest: compound 4; then compounds 1 and 3 (each within the scatter of the next). At a limit, above all of these: compound 2.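

In this assay the 1,3-thiazol-2-yl group lowers the number relative to both fluorophenyl compounds: a 3.7-fold lower number from compound 3 to compound 4 (0.56 log units; beyond the scatter) and a 2.7-fold lower number from compound 1 to compound 4 (0.43 log units; beyond the scatter) show that a six-membered aromatic ring of carbon only is not needed on this saturated ring carbon. The 4-cyanophenyl compound lies much further off, with an at least 110-fold lower number from compound 2 to compound 4 (2.07 log units; beyond the scatter) on this exchange. Compound 2 is a limit and not a number: the limit of > 25000 nM in this assay, at which 1 of the 4 values shown sits.

Open, going by these compounds, is whether the nitrogen or the sulfur of the 1,3-thiazol-2-yl group carries this step. A thiophen-2-yl or an oxazol-2-yl group in the same place would separate the two.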